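Adding trifluoromethyl to the benzyl compound

The source may hold more compounds than are shown below. What is called first, only, known or untested is meant among the compounds shown, and "the series" means these compounds.

In a functional assay on HepG2 cells (Homo sapiens) for antiproliferative activity, read by sulforhodamine B assay, with a stated time of 72 h (a higher number here means a weaker inhibitor, a lower number a stronger inhibitor), compound 1 `O=C(Cn1nc(-c2ccccc2)c2ccccc2c1=O)Nc1ccccc1` gives 13400 nM, while compound 2 `O=C(Cn1nc(Cc2ccccc2)c2ccccc2c1=O)Nc1ccccc1` gives 66000 nM, the higher and therefore weaker of the two numbers. Compound 3 `O=C(Cn1nc(Cc2ccccc2)c2ccccc2c1=O)Nc1cccc(C(F)(F)F)c1` keeps the benzyl group of compound 2 but carries trifluoromethyl in place of hydrogen on an aromatic carbon, so that phenyl becomes 3-(trifluoromethyl)phenyl: trifluoromethyl in place of hydrogen on an aromatic carbon. Going by the values given here, only one measured step is available, a 4.9-fold higher number from compound 1 to compound 2 (0.69 log units; beyond the scatter), a modest change made by putting benzyl in place of phenyl at a different place. It offers only a rough guide to how far a single change can move the number in this small set. Among the compounds with values here, no measured compound carries trifluoromethyl, so the direction is a cautious guess: a similarly modest drop is expected. The estimated change is a 1.9-fold lower number from compound 2 to compound 3 (0.28 log units; within the scatter). For compound 3, the expected value is 35000 nM, with an estimated range from 12000 nM to 100000 nM.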

Compound 3, half-maximal inhibitory concentration: 3520 nM
Beside the measured number, compound 3's estimate is 9.9-fold (1.00 log units) above it; the whole stated range lies above it.
By their numbers in this assay, from the lowest: compound 3; then compound 1; then compound 2.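

Changing phenyl to 3-(trifluoromethyl)phenyl gives a 19-fold lower number from compound 2 to compound 3 (1.27 log units; beyond the scatter) in this assay, showing that one substitution on this ring, untouched in the earlier pair, can move the number strongly. This large step exceeds the only earlier one, a 4.9-fold higher number from compound 1 to compound 2 (0.69 log units; beyond the scatter), which was made at a different place and ran toward a higher number. Nothing available explains why trifluoromethyl has this effect.

From the compounds shown here alone, whether a chlorine atom, a methoxy group or an amine at the same place would give a similar step stays open, as does the effect of trifluoromethyl elsewhere on this ring. Going by these compounds, it is also open whether the same change on compound 1, which has phenyl in place of benzyl, would produce a step of similar size.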